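The source may report more compounds than this note shows. Statements on the series, on what has been measured and on what is new or still open speak of the compounds shown alone.

Measured so far in an assay on Prostate gland for inhibition of steroid 5-alpha-reductase (Rattus norvegicus); a higher number here means a weaker inhibitor, a lower number a stronger inhibitor:
compound 1, `CCCn1ccc2cc(/C(C)=C/C(=O)Nc3ccccc3OCCCC(=O)O)ccc21`, gives 190 nM
compound 2, `CC(C)=CCn1ccc2cc(/C(C)=C/C(=O)Nc3ccccc3OCCCC(=O)O)ccc21`, gives 120 nM
compound 3, `CCCCC(CC)n1ccc2cc(/C(C)=C/C(=O)Nc3ccccc3OCCCC(=O)O)ccc21`, gives 7.1 nM

Compound 3 stands lowest of the three numbers; compound 2 is its nearest neighbour and compound 1 the furthest. Between compound 1 and compound 2 the step is small, a 1.6-fold lower number from compound 1 to compound 2 (0.20 log units; within the scatter). The two steps that reach compound 3 are large: a 27-fold lower number from compound 1 to compound 3 (1.43 log units; beyond the scatter) and a 17-fold lower number from compound 2 to compound 3 (1.23 log units; beyond the scatter). Both swap a smaller group on the aromatic nitrogen for 1-ethylpentyl, and both lower the number well beyond the scatter.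

Compound 4, `C/C(=C\C(=O)Nc1ccccc1OCCCC(=O)O)c1ccc2c(ccn2Cc2cccc(C)c2)c1`, differs from compound 3 in one place: 3-methylbenzyl in place of 1-ethylpentyl on an aromatic nitrogen. The two large steps bear on this change, but in the reverse direction, since 1-ethylpentyl now leaves again. Within the data shown here, no measured compound carries a ring on that nitrogen, so whether 3-methylbenzyl behaves more like propyl, like 3-methylbut-2-en-1-yl or like 1-ethylpentyl is not known from these numbers. A step back toward the higher numbers of compound 1 and compound 2 is therefore expected, though likely not the full distance, because 3-methylbenzyl is the larger group and the large steps of a 27-fold lower number from compound 1 to compound 3 (1.43 log units; beyond the scatter) rewarded added size. Compound 4 is estimated at 30 nM, within 8 nM to 120 nM, meaning an expected 4.2-fold higher number from compound 3 to compound 4 (0.63 log units; beyond the scatter).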

Compound 4, half-maximal inhibitory concentration: 250 nM
The estimate for compound 4 lay 8.3-fold (0.92 log units) below the measured number; the measured number lies above the stated range.
By their numbers in this assay, from the lowest: compound 3; then compounds 2, 1 and 4 (each within the scatter of the next, the first and the last beyond it).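

Among these compounds, compound 4 is the first here to carry a ring on the aromatic nitrogen, and in this assay the change gives a 35-fold higher number from compound 3 to compound 4 (1.55 log units; beyond the scatter) even though 3-methylbenzyl has 8 heavy atoms against 7 for 1-ethylpentyl. The ring-bearing group also offers no gain over the smaller open-chain groups: a 1.3-fold higher number from compound 1 to compound 4 (0.12 log units; within the scatter) stays within the scatter, and a 2.1-fold higher number from compound 2 to compound 4 (0.32 log units; beyond the scatter) is a modest step that goes slightly the wrong way for an inhibitor. Across these four compounds, the heavy-atom count of the group on this nitrogen therefore does not set the number on its own, and compound 4 goes against the idea, suggested by compound 1 and compound 3, that a larger group simply gives a stronger inhibitor.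

Cyclohexylmethyl on the same nitrogen would help show whether the aromatic ring or the overall shape of 3-methylbenzyl matters, while 1-ethylpropyl would test how much of the chain in 1-ethylpentyl is needed. The data shown offer no independent measurement that explains the loss seen with compound 4.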